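This account rests on a few compounds, and the source may have more. Where it says the series, first, only, none or still open, it means among the compounds named here.

Measured so far in a functional assay with Homo sapiens as the target; on this read-out lower numbers stand for stronger inhibition and higher numbers for weaker inhibition:
compound 1 `CC(C)[C@H](NC(=O)COc1cccc2ccccc12)C(=O)N[C@@H](CC(=O)O)C(=O)COc1cccc2ccccc12` gives 19000 nM
compound 2 `CC(C)[C@H](NC(=O)COc1cccc2ccccc12)C(=O)N[C@@H](CC(=O)O)C(=O)COc1ccc(F)c(F)c1F` gives 20600 nM

Within the data shown here, compound 2 stands level with compound 1, the only other number, within the scatter. Compound 3 `CC(C)[C@H](NC(=O)COc1cccc2ccccc12)C(=O)N[C@@H](CC(=O)O)C(=O)COc1cc(F)cc(F)c1F` carries 2,3,5-trifluorophenyl in place of 2,3,4-trifluorophenyl on an oxygen on a saturated carbon. Among the measured compounds shown here, one measured step bears on this, the exchange of naphthalen-1-yl for 2,3,4-trifluorophenyl at that place (a 1.1-fold higher number from compound 1 to compound 2 (0.04 log units; within the scatter)), and it stays within the scatter. In this assay no step beyond the scatter is therefore expected, and the estimated step is small (a 1.0-fold lower number from compound 2 to compound 3 (0.01 log units; within the scatter)). For compound 3 the expected value is 20000 nM, with an estimated range from 9000 nM to 45000 nM (expected, not measured).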

Compound 3, half-maximal inhibitory concentration: 11200 nM
The estimate for compound 3 lay 1.8-fold (0.25 log units) above the measured number, and the stated range covers the measured number.
By their numbers in this assay, from the lowest: compounds 3, 1 and 2 (each within the scatter of the next).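

In this assay the exchange of 2,3,4-trifluorophenyl for 2,3,5-trifluorophenyl on an oxygen on a saturated carbon, with the same atoms joined differently, gives a 1.8-fold lower number from compound 2 to compound 3 (0.26 log units; within the scatter) and so does not separate these two isomers. The exchange of naphthalen-1-yl for 2,3,5-trifluorophenyl gives a 1.7-fold lower number from compound 1 to compound 3 (0.23 log units; within the scatter) and so adds a second trifluorophenyl group that reads level with naphthalen-1-yl at this place. Nothing available explains these numbers.

Open, going by these compounds, is whether an amine or a carboxylic acid in place of the aromatic group here would give a step beyond the scatter.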